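Working notes on the amide variants of the shared core

This account rests on a few compounds, and the source may have more. Where it says the series, first, only, none or still open, it means among the compounds named here.

The shared core is that of compound 1 `CC(C)(C)c1ccc(C(=O)N2CCC3(CC2)C(=O)N(CC(=O)NCNS(C)(=O)=O)CN3c2ccccc2)cc1`, which in an assay on HEK293 cells for displacement of a labelled ligand from NPC1-like intracellular cholesterol transporter 1 (Homo sapiens) (on this read-out higher numbers stand for weaker inhibition and lower numbers for stronger inhibition), gives 3200 nM. Compound 2 `CC(C)(C)c1ccc(C(=O)N2CCC3(CC2)C(=O)N(CC(=O)NCCCCO)CN3c2ccccc2)cc1` gives 19200 nM in this assay, and compound 3 `CC(C)(C)c1ccc(C(=O)N2CCC3(CC2)C(=O)N(CC(=O)N2CCNCC2)CN3c2ccccc2)cc1` gives 22000 nM in this assay. Compound 3 holds the highest number of the three: a 6.9-fold higher number from compound 1 to compound 3 (0.84 log units; beyond the scatter) lies beyond the scatter, whereas a 1.1-fold higher number from compound 2 to compound 3 (0.06 log units; within the scatter) lies within it, so compounds 2 and 3 cannot be ordered against each other.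

Compound 4 `CC(C)(C)c1ccc(C(=O)N2CCC3(CC2)C(=O)N(CC(=O)NCCCCN)CN3c2ccccc2)cc1` is not yet measured. It differs from compound 3 by (4-aminobutyl)amino in place of piperazin-1-yl on a carbonyl carbon. Going by the values given here, two measured steps bear on this change. The closest is a 1.1-fold higher number from compound 2 to compound 3 (0.06 log units; within the scatter), in which a ring amide and an open-chain amide gave numbers within the scatter. The other, a 6.9-fold higher number from compound 1 to compound 3 (0.84 log units; beyond the scatter), shows that an open-chain amide can sit well below compound 3, while a 6.0-fold higher number from compound 1 to compound 2 (0.78 log units; beyond the scatter) shows that the terminal group alone moves the number by as much. Compound 4 carries the chain of compound 2 with a different terminal group. For compound 4 the expected step of a 1.2-fold lower number from compound 3 to compound 4 (0.09 log units; within the scatter) is none beyond the scatter. For compound 4 the estimate in this assay is 18000 nM, with a range from 6000 nM to 50000 nM.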

Compound 4, half-maximal inhibitory concentration: 14500 nM
Estimate against measurement, compound 4: 1.2-fold (0.09 log units) above, within the range that was stated.
By their numbers in this assay, from the lowest: compound 1; then compounds 4, 2 and 3 (each within the scatter of the next).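

Replacing the piperazin-1-yl ring with (4-aminobutyl)amino on the carbonyl carbon gives no separable change in this assay (a 1.5-fold lower number from compound 3 to compound 4 (0.18 log units; within the scatter)), and swapping the terminal hydroxy for amino leaves the open chain equally unresolved (a 1.3-fold lower number from compound 2 to compound 4 (0.12 log units; within the scatter)), so neither the ring nor this terminal exchange can be ordered at this position. Going by these compounds alone, compound 1 remains apart, with the methanesulfonamido end giving a modest separation beyond the scatter when 3-aminopropyl takes its place (a 4.5-fold higher number from compound 1 to compound 4 (0.66 log units; beyond the scatter)), so two different polar-free descriptions aside, only that end group stands out among the four compounds. No measurement shown gives a reason for any of these steps.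

The compounds shown do not separate the methanesulfonamido group from the shorter chain that carries it in compound 1. As far as these compounds go, whether a carboxylic acid at the chain end or a longer chain ending in amino would approach compound 1 also stays open.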